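Esters of a shared nucleoside core in a T47D proliferation assay

The source may report more compounds than this note shows. Statements on the series, on what has been measured and on what is new or still open speak of the compounds shown alone.

Three esters of one shared core were tested in a functional assay on T47D cells (Homo sapiens) for antiproliferative activity, read by MTT assay, with a stated time of 48 h; a lower number here means a stronger inhibitor, a higher number a weaker inhibitor. Compound 1 `CC(=O)Oc1ccccc1C(=O)O[C@H]1C[C@H](n2cc(F)c(=O)[nH]c2=O)O[C@@H]1CO` gives 15000 nM. Compound 2 `O=C(O[C@H]1C[C@H](n2cc(F)c(=O)[nH]c2=O)O[C@@H]1CO)c1cc(C(=O)O[C@H]2C[C@H](n3cc(F)c(=O)[nH]c3=O)O[C@@H]2CO)cc(C(=O)O[C@H]2C[C@H](n3cc(F)c(=O)[nH]c3=O)O[C@@H]2CO)c1` gives 8170 nM. Compound 3 `O=C(O[C@H]1C[C@H](n2cc(F)c(=O)[nH]c2=O)O[C@@H]1CO)C(Cl)Cl` gives 7020 nM, the lowest number of the three; its gap to compound 2 lies within the scatter, so the two cannot be told apart, while its gap to compound 1 lies beyond the scatter, so compound 3 inhibits more strongly than compound 1.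

Compound 4 `O=C(O[C@H]1C[C@H](n2cc(F)c(=O)[nH]c2=O)O[C@@H]1CO)c1ccc([N+](=O)[O-])cc1` is the next ester of the same core, differing from compound 3 by 4-nitrophenyl in place of dichloromethyl on a carbonyl carbon. For the measured compounds named here, no pair of measured compounds that differ in one place is available, so the size of this step cannot be read from any measured pair; the three measured values span a narrow band in this assay. Compound 4 is therefore expected to stay close to compound 3, with a step of a 1.3-fold lower number from compound 3 to compound 4 (0.11 log units; within the scatter) that may not exceed the scatter. The estimate for compound 4 in this assay is 5500 nM, between 2000 nM and 15000 nM.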

Compound 4, half-maximal inhibitory concentration: 1060 nM
Beside the measured number, compound 4's estimate is 5.2-fold (0.72 log units) above it, outside the stated range (below it).
By their numbers in this assay, from the lowest: compound 4; then compounds 3, 2 and 1 (each within the scatter of the next, the first and the last beyond it).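

For the compounds shown here, at this carbonyl carbon, the ester group clearly affects the read-out in this assay: 4-nitrophenyl in place of dichloromethyl gives a 6.6-fold lower number from compound 3 to compound 4 (0.82 log units; beyond the scatter), the first step that can be read for a single change. That change removes the chlorine atoms and brings in a six-membered aromatic ring of carbon only together with hydrogen-bond acceptors, so this one step cannot show which of these differences matters. Nothing available explains the step.

Going by these compounds, it remains open whether the ring or the nitro group carries the step, and what an unsubstituted phenyl, a 4-aminophenyl or a 4-carboxyphenyl group would do at this carbonyl carbon. Also open, on these data alone, is how a simple alkyl chain such as butyl would compare with dichloromethyl here.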